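A few compounds are considered here, and "the series" means these few. Any claim that something is new, unique, unknown or untested is made for them only; others in the source may bear on it.

Compound 2, with the structure `COc1cc(OC)cc(/C(=C\c2cn(C(C)=O)c3ccc(OCc4ccccc4)cc23)C(=O)O)c1`, was examined in a functional assay on LNCaP cells (Homo sapiens) for cytotoxicity, read by MTT assay, with a stated time of 72 h (a higher number here means a weaker inhibitor, a lower number a stronger inhibitor), where compound 2 gave 26100 nM. This stands as the lower of the two numbers recorded so far. The other is that of compound 1, with the structure `CC(=O)n1cc(/C=C(/C(=O)O)c2ccc(OCc3ccccc3)cc2)c2cc(OCc3ccccc3)ccc21`; in this assay compound 1 gave 77700 nM, a number that lies beyond the usual scatter above that of compound 2. Among the measured compounds shown here, no single-change step between measured compounds is available, so the account rests on these two values alone.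

Compound 3, with the structure `COc1ccc(/C(=C\c2cn(C(C)=O)c3ccc(OCc4ccccc4)cc23)C(=O)O)cc1`, carries one change relative to compound 2: 4-methoxyphenyl in place of 3,5-dimethoxyphenyl on a double-bonded chain carbon bound to a carbonyl carbon and a double-bonded chain carbon. It has not yet been measured in this assay. For the measured compounds named here, since no measured step covers this change, the size of its effect is uncertain; a step of modest size is expected, most likely toward a somewhat higher number or none beyond the scatter, with the estimated step from compound 2 to compound 3 in this assay being a 1.3-fold higher number from compound 2 to compound 3 (0.13 log units; within the scatter). Compound 3 is therefore expected to give about 35000 nM in this assay, within a range from 12000 nM to 100000 nM.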

Compound 3, half-maximal inhibitory concentration: 85000 nM
Beside the measured number, compound 3's estimate is 2.4-fold (0.39 log units) below it; measured number inside the range.
By their numbers in this assay, from the lowest: compound 2; then compounds 1 and 3 (each within the scatter of the next).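

In this assay, among the compounds shown here, 4-methoxyphenyl in place of 3,5-dimethoxyphenyl on a double-bonded chain carbon bound to a carbonyl carbon and a double-bonded chain carbon gives a 3.3-fold higher number from compound 2 to compound 3 (0.51 log units; beyond the scatter), the first measured step at this position, and it shows that the number responds to the aromatic group carried there. The other new comparison, hydrogen in place of phenyl on a saturated chain carbon bound to an oxygen on an aromatic ring, gives a 1.1-fold higher number from compound 1 to compound 3 (0.04 log units; within the scatter), so this change produces no difference that can be told from the scatter. Nothing measured on these compounds accounts for either result.

The step between 3,5-dimethoxyphenyl and 4-methoxyphenyl alters both how many methoxy groups the ring carries and where they stand, and the compounds shown cannot separate these two parts of the change. They also leave open how the number would respond at this position to an unsubstituted phenyl or to a phenyl carrying an amine or a fluorine atom.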